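The source may hold more compounds than are shown below. What is called first, only, known or untested is meant among the compounds shown, and "the series" means these compounds.

Measured in a functional assay on NCI-H630 cells (Homo sapiens) for cytotoxicity, read by sulforhodamine B assay, with a stated time of 5 days; a higher number here means a weaker inhibitor, a lower number a stronger inhibitor:

- Compound 1 `O=C(CCCCCc1ccccc1)N[C@H]1CCOC1=O`: > 100000 nM (a limit of the assay)
- Compound 2 `O=C(CCCCCc1ccccc1)CC(=O)N[C@H]1CCOC1=O`: 24000 nM
- Compound 3 `O=C(CCCCCCCCCCc1ccccc1)CC(=O)N[C@H]1CCOC1=O`: 14000 nM

Compound 1 gives no number, only a limit, and stands at the limit of > 100000 nM in this assay, at which 1 of the 3 values shown sits. Compound 2 at 24000 nM and compound 3 at 14000 nM do give numbers, and these two lie within the usual scatter of each other.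

The next compound to be read is compound 4 `O=C(CCCCCCc1ccccc1)N[C@H]1CCOC1=O`. It departs from compound 1 in one place: benzyl in place of phenyl on a saturated chain carbon, five bonds along the chain from a carbonyl carbon. In words, this is benzyl in place of phenyl on a saturated chain carbon, five bonds along the chain from a carbonyl carbon.

Among the measured compounds shown here, no measured step speaks directly to this change, so the expectation in this assay is of no shift beyond the scatter, with no direction favoured. The estimated change is a number no higher from compound 1 to compound 4 (the limit leaves the size open). A report of a limit alone is also expected to be quite likely. For compound 4 the expected value is 100000 nM, with an estimated range from 40000 nM to 250000 nM.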

Compound 4, half-maximal inhibitory concentration: > 100000 nM
Compound 4: no number, only a limit (the forecaster's own chance of this, stated with the estimate: 65%); the middle value sits exactly at the limit.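

Compound 4, like compound 1, gives only a limit and no number in this assay, so no step between the two can be read: the limit of > 100000 nM in this assay, at which 2 of the 4 values shown sit.

The compounds shown leave open whether benzyl in place of phenyl changes the value at all, and in which direction.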